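The source may report more compounds than this note shows. Statements on the series, on what has been measured and on what is new or still open speak of the compounds shown alone.

Compound 1 `Fc1ccccc1Cn1cc(CSC(=S)N2CCNCC2)nn1`: in a functional assay on ECa-109 cells (Homo sapiens) for inhibition, read by MTT assay, with a stated time of 72 h (on this read-out lower numbers stand for stronger inhibition and higher numbers for weaker inhibition), compound 1 gives > 128000 nM, which is a limit of the assay rather than a number.
Compound 2 `S=C(SCc1cn(Cc2ccc(Cl)c(Cl)c2)nn1)N1CCNCC1`: in this assay compound 2 gives > 128000 nM, again a limit of the assay.
Compound 3 `O=C(OCc1ccccc1)N1CCN(C(=S)SCc2cn(Cc3ccc(Cl)c(Cl)c3)nn2)CC1`: in this assay compound 3 gives 29400 nM.

Compound 2 therefore stands at the weak end of what has been measured, with only a limit to its name; it sits at the limit of > 128000 nM in this assay, at which 2 of the 3 values shown sit. The compound to be measured next is compound 4 `Fc1ccc(Cn2cc(CSC(=S)N3CCNCC3)nn2)cc1`, which differs from compound 2 in one place: 4-fluorophenyl in place of 3,4-dichlorophenyl on a saturated chain carbon bound to an aromatic nitrogen. Within the data shown here, the one measured step that changes the same place is a step that the two limits leave unreadable from compound 1 to compound 2, and it gives no guide to the size of such a swap. Among the measured compounds shown here, the only readable step, an at least 4.3-fold lower number from compound 2 to compound 3 (0.63 log units; beyond the scatter), concerns a different place, the amine nitrogen in a ring, and compound 4 keeps that nitrogen as in compound 2. Nothing measured here suggests that exchanging one halogenated phenyl for another moves the number away from the limit. Compound 4 is therefore expected to stay at or near the limit, with a step that the limit leaves unreadable from compound 2 to compound 4 as the expected step. The estimate for compound 4 in this assay is 200000 nM, within a range from 100000 nM to 600000 nM.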

Compound 4, half-maximal inhibitory concentration: > 128000 nM
Compound 4: a limit, no number; the forecaster's own chance of this, stated with the estimate: 75%; the middle value lies beyond the limit too.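

Compound 4, like compound 1 and compound 2, gives only a limit of the assay rather than a number, so the steps among these three compounds cannot be read. On these data alone, what stays open is whether 2-fluorophenyl, 4-fluorophenyl and 3,4-dichlorophenyl differ at all in their effect, including on a compound with a readable value, such as compound 3.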